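This account rests on a few compounds, and the source may have more. Where it says the series, first, only, none or still open, it means among the compounds named here.

Values in a functional assay on MCF7 cells (Homo sapiens) for antiproliferative activity; on this read-out lower numbers stand for stronger inhibition and higher numbers for weaker inhibition:
- compound 1 `CC(C)=CCc1cc(C(=O)Nc2cc3ccc(OCCCNC(C)C)c(C)c3oc2=O)ccc1O`: 740 nM
- compound 2 `CC(C)=CCc1cc(C(=O)Nc2cc3ccc(OCCCNC(C)(C)C)c(C)c3oc2=O)ccc1O`: 950 nM
- compound 3 `CC(C)=CCc1cc(C(=O)Nc2cc3ccc(OCCCNCC(N)=O)c(C)c3oc2=O)ccc1O`: 1460 nM

Compound 3 lies within the scatter of compound 1 and compound 2. The next entry is compound 4 `CC(C)=CCc1cc(C(=O)Nc2cc3ccc(OCCCNCCO)c(C)c3oc2=O)ccc1O`, with the change hydroxymethyl in place of carbamoyl on a saturated chain carbon bound to an amine nitrogen. Going by the values given here, no measured step makes this exact swap. The closest steps change the substituent on the same amine nitrogen: a 2.0-fold higher number from compound 1 to compound 3 (0.30 log units; within the scatter) and a 1.5-fold higher number from compound 2 to compound 3 (0.19 log units; within the scatter), alongside a 1.3-fold higher number from compound 1 to compound 2 (0.11 log units; within the scatter). All three stay within the scatter, so no step beyond it is expected in this assay. The expected step is a 1.2-fold lower number from compound 3 to compound 4 (0.09 log units; within the scatter). For compound 4 the estimate is 1200 nM, with an expected range from 550 nM to 2500 nM.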

Compound 4, half-maximal inhibitory concentration: 1560 nM
The estimate for compound 4 lay 1.3-fold (0.11 log units) below the measured number; low and high end bracket the measured number.
By their numbers in this assay, from the lowest: compounds 1, 2, 3 and 4 (each within the scatter of the next, the first and the last beyond it).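

In this assay hydroxymethyl in place of carbamoyl on a saturated chain carbon bound to an amine nitrogen stays within the scatter (a 1.1-fold higher number from compound 3 to compound 4 (0.03 log units; within the scatter)), so this exchange leaves no readable change. With 2-hydroxyethyl on the amine nitrogen, the step from tert-butyl also stays within the scatter (a 1.6-fold higher number from compound 2 to compound 4 (0.22 log units; within the scatter)), whereas the step from isopropyl is the only one here beyond it, and modest (a 2.1-fold higher number from compound 1 to compound 4 (0.32 log units; beyond the scatter)). No evidence on the origin of these steps is available.

Going by these compounds, whether a carboxylic acid or a longer chain ending in hydroxyl on the amine nitrogen would move the number further remains open.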